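A few compounds are considered here, and "the series" means these few. Any claim that something is new, unique, unknown or untested is made for them only; others in the source may bear on it.

The three compounds measured in an assay for inhibition of leukotriene C4 synthase (Homo sapiens), read by LC-MS, with stated times of 15 min and 30 min; a lower number here means a stronger inhibitor, a higher number a weaker inhibitor:

compound 1, `COc1cc(N(CC2CC2)c2ccc(Cl)c(Cl)c2)cnc1C(=O)[C@H]1C[C@@H]1C(=O)O`, compound 1 gives 4.94 nM
compound 2, `COc1cc(N(CC2CC2)c2ccccc2)cnc1C(=O)[C@H]1C[C@@H]1C(=O)O`, compound 2 gives 158 nM
compound 3, `COc1cc(N(CC2CC2)c2cc(C(F)(F)F)ccc2F)cnc1C(=O)[C@H]1C[C@@H]1C(=O)O`, compound 3 gives 2.08 nM

Compound 3 holds the lowest number of the three in this assay. Compound 1 gives 4.94 nM, a higher number than compound 3, and compound 2 gives 158 nM, a number far higher than either of the other two. Compound 4, `COc1cc(N(CC2CC2)c2cc(Cl)ccc2F)cnc1C(=O)[C@H]1C[C@@H]1C(=O)O`, has not yet been measured. It differs from compound 3 in one place: chloro in place of trifluoromethyl on an aromatic carbon.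

For the measured compounds named here, only one measured step speaks to changes on this ring. Going a 32-fold higher number from compound 1 to compound 2 (1.50 log units; beyond the scatter) shows that stripping the ring of its substituents costs a great deal in this assay. The change from compound 3 to compound 4 is of a different kind: one substituent is swapped for another, and the fluoro group stays. Compound 1 shows that a chloro-bearing ring can give a low number, with 4.94 nM, so the step of a 1.7-fold higher number from compound 3 to compound 4 (0.23 log units; within the scatter) is expected to be small, perhaps a slight rise, or none beyond the scatter. Compound 4 is therefore estimated to give 3.5 nM, with a range from 1.2 nM to 12 nM.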

Compound 4, half-maximal inhibitory concentration: 3.71 nM
Beside the measured number, compound 4's estimate is 1.1-fold (0.03 log units) below it, and the stated range covers the measured number.
By their numbers in this assay, from the lowest: compounds 3, 4 and 1 (each within the scatter of the next, the first and the last beyond it); then compound 2.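

In this assay, putting chloro in place of trifluoromethyl on this aromatic carbon, meta to a large group and para to a fluoro group, gives a 1.8-fold higher number from compound 3 to compound 4 (0.25 log units; within the scatter) and so leaves the two groups indistinguishable at this place, although one has four heavy atoms and the other has one. The step of a 43-fold lower number from compound 2 to compound 4 (1.63 log units; beyond the scatter) shows that a second substituted ring, with its halogens placed differently from those of compound 1, also stands far from the bare phenyl of compound 2, so the large gain seen earlier is not confined to 3,4-dichlorophenyl. The step of a 1.3-fold lower number from compound 1 to compound 4 (0.12 log units; within the scatter) lies within the scatter, so 5-chloro-2-fluorophenyl and 3,4-dichlorophenyl cannot be told apart in this assay, and nothing shown bears on what lies behind any of these numbers.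

On these data alone, what the fluoro group contributes on its own stays open, since it is present in both compound 3 and compound 4. Also open, as far as these compounds go, is whether a nitrile or a methoxy group on this carbon would stay within the scatter of chloro and trifluoromethyl.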